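This account rests on a few compounds, and the source may have more. Where it says the series, first, only, none or still open, it means among the compounds named here.

Values so far in a functional assay on DU-145 cells (Homo sapiens) for inhibition, read by trypan blue exclusion, with a stated time of 96 h; a higher number here means a weaker inhibitor of growth, a lower number a stronger inhibitor of growth:
- Compound 1 `Cc1ccc(CS/C(=C/c2ccc(Br)cc2)C(=O)c2ccc(Cl)cc2)cc1`: 10000 nM
- Compound 2 `O=C(/C(=C\c1ccc(Br)cc1)Sc1ccc(Br)cc1)c1ccc(Cl)cc1`: 1000 nM

Compound 2 holds the lower of the two numbers, so it is the stronger growth inhibitor of this pair. Next is compound 3 `O=C(/C(=C\c1ccc(Br)cc1)SCc1ccc(F)cc1)c1ccc(Cl)cc1`, with 4-fluorobenzyl in place of 4-bromophenyl on a sulfur. Among the compounds with values here, one measured step bears on this change: a 10-fold lower number from compound 1 to compound 2 (1.00 log units; beyond the scatter), modest but beyond the scatter, for 4-bromophenyl in place of 4-methylbenzyl on the same sulfur. Compound 3 returns to a benzyl group on that sulfur, so most of that step is expected to be given back, although a single step is thin support and the effect of the fluorine is unmeasured. The expected change is a 6.0-fold higher number from compound 2 to compound 3 (0.78 log units; beyond the scatter). For compound 3 the estimated value is 6000 nM, with an expected range of 2000 nM to 15000 nM.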

Compound 3, concentration for 50% growth inhibition: 9000 nM
Beside the measured number, compound 3's estimate is 1.5-fold (0.18 log units) below it, and the stated range covers the measured number.
By their numbers in this assay, from the lowest: compound 2; then compounds 3 and 1 (each within the scatter of the next).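

In this assay, the change from the directly attached 4-bromophenyl to 4-fluorobenzyl on this sulfur gives a 9.0-fold higher number from compound 2 to compound 3 (0.95 log units; beyond the scatter), so both benzyl compounds now sit on the weaker side of the earlier step, a 10-fold lower number from compound 1 to compound 2 (1.00 log units; beyond the scatter), and the lower number belongs to compound 2 alone. Within the benzyl pair, fluoro in place of methyl on the aromatic carbon gives a 1.1-fold lower number from compound 1 to compound 3 (0.05 log units; within the scatter), so this swap has no effect that can be resolved here. The data shown offer no measurement that explains why the 4-bromophenyl compound differs from the two benzyl compounds.

Within the data shown here, with compound 2 as the only directly attached aryl example, it remains open whether the gain belongs to aryl groups on this sulfur generally or to 4-bromophenyl specifically. Also open, going by these compounds, is how an amine, a carboxylic acid or a longer chain on this sulfur would fare.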